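From compound 2 to compound 3: one group exchanged

This account rests on a few compounds, and the source may have more. Where it says the series, first, only, none or still open, it means among the compounds named here.

Compound 1 `COc1cccc(/C=C/C(=O)Oc2ccc(C(C)=O)cc2)c1` gives > 2780000 nM as a limit
Compound 2 `COc1cccc(/C=C/C(=O)OC[C@H]2O[C@@H](Oc3ccc(C(C)=O)cc3)[C@H](O)[C@@H](O)[C@@H]2O)c1` gives > 1510000 nM as a limit

In an ADME assay on HepG2 2.2.15 cells (Homo sapiens) for cytotoxicity, read by MTT assay (on this read-out lower numbers stand for higher toxicity in this test and higher numbers for lower toxicity in this test), compound 2 stands only at a limit, > 1510000 nM and no number. Compound 1 likewise gives > 2780000 nM as a limit only. Compound 3 `CC(=O)c1ccc(O[C@@H]2O[C@H](COC(=O)c3cccs3)[C@@H](O)[C@H](O)[C@H]2O)cc1` carries thiophen-2-yl in place of 2-(3-methoxyphenyl)ethenyl on a carbonyl carbon and otherwise matches compound 2. For the measured compounds named here, no measured pair shows such a change, so in this assay no shift beyond the scatter is expected. The expected step that the limit leaves unreadable from compound 2 to compound 3 stays small. Compound 3 is estimated at 1800000 nM with an expected range from 700000 nM to 3500000 nM and may well return only a limit.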

Compound 3, half-maximal cytotoxic concentration: 1570000 nM
For compound 3 the middle estimate is 1.1-fold (0.06 log units) above the measured one; the range from low to high includes it.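

In this assay, no step can be read from compound 2 to compound 3, because compound 2 stands only at a limit: the limit of > 1510000 nM in this assay, at which 1 of the 3 values shown sits.

The compounds shown leave open whether thiophen-2-yl in place of 2-(3-methoxyphenyl)ethenyl changes the toxicity in this test at all.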